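The source may report more compounds than this note shows. Statements on the series, on what has been measured and on what is new or still open speak of the compounds shown alone.

Among the three measured compounds, compound 3 `COC(=O)NC[C@H]1CN(c2ccc(-n3cc(-c4ccccn4)cn3)c(F)c2)C(=O)O1` gives the lowest number in a physicochemical assay for solubility, read by HPLC, with a stated time of 24 h (on this read-out higher numbers stand for higher solubility and lower numbers for lower solubility), at 34100 nM. Compound 2 `O=C1CCC(=O)N1C[C@H]1CN(c2ccc(-n3cc(-c4ccccn4)cn3)c(F)c2)C(=O)O1` gives 45300 nM in this assay, and compound 1 `CCN1CCN(C[C@H]2CN(c3ccc(-n4cc(-c5ccccn5)cn4)c(F)c3)C(=O)O2)CC1` gives 706000 nM; the steps of a 16-fold lower number from compound 1 to compound 2 (1.19 log units; beyond the scatter) and a 21-fold lower number from compound 1 to compound 3 (1.32 log units; beyond the scatter) were large, whereas a 1.3-fold lower number from compound 2 to compound 3 (0.12 log units; within the scatter) stayed within the scatter. Compound 4 `CNC(=O)[C@H]1CN(c2ccc(-n3cc(-c4ccccn4)cn3)c(F)c2)C(=O)O1` differs from compound 3 by methylcarbamoyl in place of ((methoxycarbonyl)amino)methyl on a saturated ring carbon. Within the data shown here, no measured step touches that ring carbon; the only step between two uncharged groups, from compound 2 to compound 3, was within the scatter, so a step of similar size is expected here. For compound 4 the estimate in this assay is 30000 nM, with a range from 10000 nM to 90000 nM, which would mean a 1.1-fold lower number from compound 3 to compound 4 (0.06 log units; within the scatter).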

Compound 4, solubility: 26200 nM
For compound 4 the middle estimate is 1.1-fold (0.06 log units) above the measured one; low and high end bracket the measured number.
By their numbers in this assay, from the lowest: compounds 4, 3 and 2 (each within the scatter of the next); then compound 1.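

In this assay, methylcarbamoyl on the saturated ring carbon, with no chain carbon in between, gave a 1.3-fold lower number from compound 3 to compound 4 (0.11 log units; within the scatter) and a 1.7-fold lower number from compound 2 to compound 4 (0.24 log units; within the scatter), so these replacements of ((methoxycarbonyl)amino)methyl and (2,5-dioxopyrrolidin-1-yl)methyl left the read-out within the scatter. Only the replacement of (4-ethylpiperazin-1-yl)methyl gave a large step, a 27-fold lower number from compound 1 to compound 4 (1.43 log units; beyond the scatter), and compound 1 remains apart from the other three. Nothing measured accounts for these steps. Open, on these data alone, is whether an amine or a carboxylic acid on this ring carbon would stand apart as compound 1 does, or stay with compound 4.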